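A few compounds are considered here, and "the series" means these few. Any claim that something is new, unique, unknown or untested is made for them only; others in the source may bear on it.

Of the compounds shown here, three of related build have been tested in a functional assay on A2780 cells (Homo sapiens) for inhibition, read by MTT assay, with a stated time of 72 h; on this read-out higher numbers stand for weaker inhibition of growth and lower numbers for stronger inhibition of growth. Compound 1 `N#C/C(=C\c1ccc([N+](=O)[O-])cc1)C(=O)c1c[nH]c2ccccc12` gives 48000 nM in this assay. Compound 2 `COc1ccc(CNC(=O)/C(C#N)=C/c2ccco2)cc1` gives 24000 nM in this assay, and the number for compound 1 lies within the usual scatter of that, so the two cannot be told apart. Compound 3 `N#C/C(=C\c1ccco1)C(=O)NCc1ccc(Cl)c(Cl)c1` gives > 50000 nM in this assay, which is a limit of the measurement and not a number. This value of compound 3 sits at the limit of > 50000 nM in this assay, at which 1 of the 3 values shown sits.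

The next compound to be measured is compound 4 `COc1ccc(CNC(=O)/C(C#N)=C/c2ccc(Br)o2)cc1`. It differs from compound 2 in one place: bromo in place of hydrogen on an aromatic carbon. Within the data shown here, no measured pair in this set shows what such a change does, so there is nothing to compare against, and the step is expected to be small, in no clear direction, and not beyond the scatter. Compound 4 is therefore expected to give about 22000 nM in this assay, with a range from 7000 nM to 60000 nM. That estimate amounts to a step of a 1.1-fold lower number from compound 2 to compound 4 (0.04 log units; within the scatter) that is expected to stay within the scatter.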

Compound 4, concentration for 50% growth inhibition: 12000 nM
Estimate against measurement, compound 4: 1.8-fold (0.26 log units) above; measured number inside the range.
By their numbers in this assay, from the lowest: compounds 4, 2 and 1 (each within the scatter of the next, the first and the last beyond it). At a limit, above all of these: compound 3.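

Among these compounds, this is the first pair in the set that differs in one place, and going from furan-2-yl to 5-bromofuran-2-yl in this assay gives a 2.0-fold lower number from compound 2 to compound 4 (0.30 log units; within the scatter) and so stays within the scatter. Bromo can therefore stand on this aromatic carbon, next to the ring oxygen, with compound 4 not distinguishable from compound 2 in growth inhibition. Nothing measured here gives a reason for the size of this step.

On these data alone, whether another group on the same carbon, such as chloro, methyl or an amine, would give a step beyond the scatter remains open. As far as these compounds go, compound 3 gives > 50000 nM as a limit of the assay and not a number, so it remains open whether bromo on its ring would bring a measurable value.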